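This account rests on a few compounds, and the source may have more. Where it says the series, first, only, none or still open, it means among the compounds named here.

In a functional assay, with a stated time of 150 min, tested at 5 ug/mL (a lower number here means a weaker effect, a higher number a stronger effect of the compound at the concentration tested), compound 1, `COC(=O)c1c(Nc2ccccc2)sc(C(=O)c2ccc(OC)cc2)c1C`, gives 13.3%. Compound 2, `COC(=O)c1c(Nc2ccc(Cl)cc2)sc(C(=O)c2ccc(OC)cc2)c1C`, is reported in this assay as "not active" (no number reported), without a number. Compound 3, `COc1ccc(C(=O)c2sc(Nc3ccccc3)c(C(=O)O)c2C)cc1`, gives 19.6% in this assay. Among the two numbers compound 3 stands at one end with compound 1 next to it, and the single measured step, a number 6.3 percentage points higher from compound 1 to compound 3 (within the scatter), is within the scatter.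

Compound 4, `COc1ccc(Nc2sc(C(=O)c3ccc(OC)cc3)c(C)c2C(=O)O)cc1`, differs from compound 3 by methoxy in place of hydrogen on an aromatic carbon. For the measured compounds named here, no measured step in this assay puts a methoxy group on that ring, so none bears directly on the change. The pair of compound 1 and compound 2 shows what a group at this place has done so far: compound 1 gives 13.3% and compound 2 gives "not active" (no number reported). Compound 4 is therefore expected in this assay to lie lower than compound 3 or within the scatter of it, with a number 9.6 percentage points lower from compound 3 to compound 4 (within the scatter) as the estimated step, and an appreciable chance that no number is reported. The estimate for compound 4 is 10%, between 0% and 25%.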

Compound 4, a percentage reported as activity, at one concentration (the size of the read-out at that concentration, not a potency): 20.2%
Beside the measured number, compound 4's estimate is 10.2 percentage points below it; the measured number falls inside the stated range.
By their numbers in this assay, from the lowest: compounds 1, 3 and 4 (each within the scatter of the next).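

In this assay, methoxy in place of hydrogen on this aromatic carbon, para to a large group, comes out as a number 0.6 percentage points higher from compound 3 to compound 4 (within the scatter) and cannot be told apart from hydrogen at this place. For the compounds shown here, the only earlier change on this ring, chloro in compound 2 against hydrogen in compound 1, ended in a report without a number, whereas methoxy on compound 3 still yields a number, so a group here does not always cost the number. Nothing given here accounts for this result. The compounds shown leave open whether chloro on compound 3 would still give a number and whether methoxy on compound 1 would. They also leave open whether an amine or a longer chain such as butoxy at this place would give a step beyond the scatter.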